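This account rests on a few compounds, and the source may have more. Where it says the series, first, only, none or still open, it means among the compounds named here.

Three compounds from this series have been characterised in an assay on HEK293 cells for displacement of a labelled ligand from NPC1-like intracellular cholesterol transporter 1 (Homo sapiens); on this read-out higher numbers stand for weaker inhibition and lower numbers for stronger inhibition. Compound 2, `CC(C)(C)OC(=O)NC1CCCN(C(=O)CN2CN(c3ccccc3)C3(CCN(C(=O)c4ccc(C(C)(C)C)cc4)CC3)C2=O)C1`, gives 4200 nM and stands second highest of the three numbers. Its nearest neighbour is compound 3, `O=C(CN1CN(c2ccccc2)C2(CCN(C(=O)c3ccc(C4CCCCC4)cc3)CC2)C1=O)NCCO`, which in this assay gives 2000 nM, a lower number that lies beyond the scatter. The furthest is compound 1, `CC(C)(C)c1ccc(C(=O)N2CCC3(CC2)C(=O)N(CC(=O)NCCC(=O)O)CN3c2ccccc2)cc1`, which in this assay gives 11400 nM, a higher number that also lies beyond the scatter.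

Compound 4, `CC(C)(C)c1ccc(C(=O)N2CCC3(CC2)C(=O)N(CC(=O)N2CCCC(CO)C2)CN3c2ccccc2)cc1`, has not yet been measured. It differs from compound 2 in one place: hydroxymethyl in place of (tert-butoxycarbonyl)amino on a saturated ring carbon. Going by the values given here, no measured pair in the set shows this change on its own, so there is no step to rest on directly. What can be said is that the hydroxyl-bearing compound 3 gives the lowest number shown, while the carboxylic-acid-bearing compound 1 gives the highest. On that basis compound 4 is expected to give a number close to that of compound 2 or a little lower, with the expected step of a 1.4-fold lower number from compound 2 to compound 4 (0.15 log units; within the scatter) likely within the scatter. The estimate for compound 4 in this assay is 3000 nM, with a range from 1200 nM to 8000 nM.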

Compound 4, half-maximal inhibitory concentration: 8200 nM
Beside the measured number, compound 4's estimate is 2.7-fold (0.44 log units) below it, and the stated range ends below it.
By their numbers in this assay, from the lowest: compound 3; then compounds 2, 4 and 1 (each within the scatter of the next, the first and the last beyond it).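

In this assay, hydroxymethyl in place of (tert-butoxycarbonyl)amino on a saturated ring carbon gives a 2.0-fold higher number from compound 2 to compound 4 (0.29 log units; within the scatter), so at this place a group of 8 heavy atoms gives way to one of 2 without a step that stands clear of the scatter. At the same end of the molecule, 3-(hydroxymethyl)piperidin-1-yl in place of (2-carboxyethyl)amino on a carbonyl carbon gives a 1.4-fold lower number from compound 1 to compound 4 (0.14 log units; within the scatter), so this exchange, which removes the carboxylic acid, is not resolved from the scatter either. Nothing measured here offers an explanation for either step.

The compounds shown leave open what a free amine or a longer chain ending in a hydroxyl would give on this saturated ring carbon. They also leave open what cyclohexyl in place of tert-butyl does on its own.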